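Sulfonamide pyridines tested against tissue-nonspecific alkaline phosphatase

The source may report more compounds than this note shows. Statements on the series, on what has been measured and on what is new or still open speak of the compounds shown alone.

Measured compounds:
compound 1, `CNC(=O)c1cncc(NS(=O)(=O)c2cc(Cl)ccc2OC)c1`, > 20000 nM
compound 2, `COc1ccc(Cl)cc1S(=O)(=O)Nc1cncc(C(=O)Nc2ccccc2)c1`, "not determined" (no result reported)

In an assay on isolated protein for inhibition of alkaline phosphatase, tissue-nonspecific isozyme (Homo sapiens) (a higher number here means a weaker inhibitor, a lower number a stronger inhibitor), compound 1 gives > 20000 nM, which is a limit of the assay and not a number. Among the measured compounds shown here, for compound 2 no result was reported in this assay, so it cannot be placed among the measured values; the only other value shown for the series is the limit of compound 1, as described by the limit of > 20000 nM in this assay, at which 1 of the 2 values shown sits. For the measured compounds named here, no step between two measured compounds is therefore available.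

Compound 3, `COc1ccc(Cl)cc1S(=O)(=O)Nc1cncc(-c2ccncc2)c1`, differs from compound 2 by pyridin-4-yl in place of phenylcarbamoyl on an aromatic carbon. Going by the values given here, with no measured step to lean on and compound 1 at the limit in this assay, the size and direction of the change from compound 2 to compound 3 in this assay cannot be judged beyond expecting weak inhibition. Compound 3 is expected to give 15000 nM, with a range from 2000 nM to 60000 nM.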

Compound 3, half-maximal inhibitory concentration: > 20000 nM
Compound 3 was reported as a limit; the forecaster's own chance of this, stated with the estimate: 55%; middle value at least 1.3-fold (0.12 log units) from the limit.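

Among the compounds shown here, compound 1 and compound 3 both stand at a limit of the assay in this assay, so no step between them can be read: the limit of > 20000 nM in this assay, at which 2 of the 3 values shown sit. The compounds shown leave open whether any group at this place on the shared core gives a readable value in this assay.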